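This account rests on a few compounds, and the source may have more. Where it says the series, first, only, none or still open, it means among the compounds named here.

Of the compounds shown here, three that share one core have been tested in a functional assay on MDA-MB-435 cells (Homo sapiens) for cytotoxicity, read by MTT assay, with a stated time of 72 h; on this read-out higher numbers stand for weaker inhibition and lower numbers for stronger inhibition. Compound 1 `O=C(NCc1ccc(F)cc1)c1nc(Br)c2cccnc2c1NCCO` gives > 20000 nM, which is a limit of the assay and not a number. Compound 3 `O=C(NCc1ccc(F)cc1)c1nc(Br)c2cccnc2c1NCc1ccccc1` gives > 20000 nM, which is also only a limit. Compound 3 therefore has no exact value and stands at the limit of > 20000 nM in this assay, at which 2 of the 3 values shown sit. Compound 2 `CNCCCNc1c(C(=O)NCc2ccc(F)cc2)nc(Br)c2cccnc12` gives a measured number, 11000 nM.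

Compound 4 `NCCCCCCNc1c(C(=O)NCc2ccc(F)cc2)nc(Br)c2cccnc12` has not yet been measured. Its difference from compound 3 is 5-aminopentyl in place of phenyl on a saturated chain carbon bound to a nitrogen on an aromatic ring. In words, 5-aminopentyl replaces phenyl on a saturated chain carbon bound to a nitrogen on an aromatic ring.

The most useful comparison is an at least 1.8-fold higher number from compound 2 to compound 3 (0.25 log units; that floor lies within the scatter), since compound 2 also has an open chain carrying an amino group. The other readable step is an at least 1.8-fold lower number from compound 1 to compound 2 (0.25 log units; that floor lies within the scatter). Neither establishes a real change, and a step that the two limits leave unreadable from compound 1 to compound 3 adds nothing on size. Still, the expectation for compound 4 leans on compound 2 with its 11000 nM. The expected step in this assay is an at least 2.2-fold lower number from compound 3 to compound 4 (0.34 log units; beyond the scatter), towards stronger inhibition, though this remains tentative. For compound 4 the estimated value is 9000 nM, with an expected range from 3500 nM to 20000 nM.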

Compound 4, half-maximal inhibitory concentration: 6000 nM
Estimate against measurement, compound 4: 1.5-fold (0.18 log units) above, and the stated range covers the measured number.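

In this assay, two steps at this position now pass the scatter, an at least 3.3-fold lower number from compound 3 to compound 4 (0.52 log units; beyond the scatter) and an at least 3.3-fold lower number from compound 1 to compound 4 (0.52 log units; beyond the scatter), whereas the earlier readable steps both stayed within it. Among these compounds, both new steps give only a smallest possible size, because compound 1 and compound 3 each sit at a limit of the assay and not at a number: the limit of > 20000 nM in this assay, at which 2 of the 4 values shown sit. Against compound 2, whose chain is shorter and ends in methylamino, the change is a 1.8-fold lower number from compound 2 to compound 4 (0.26 log units; within the scatter), so the 6-aminohexyl chain cannot be ranked above that chain, and what the data support is only that both amine-bearing compounds sit apart from the limit, with compound 4 clearly so.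

The compounds shown do not separate the part played by the amine from the part played by the chain length, since no chain here has one without the other. A plain hexyl chain with no amine would pull these two apart, and a chain ending in a carboxylic acid, or a longer chain ending in an amine, would show how far the trend extends.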